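Replacing a thioether chain with an amide chain on the indole core

The source may hold more compounds than are shown below. What is called first, only, known or untested is meant among the compounds shown, and "the series" means these compounds.

The series is measured in an assay on isolated protein (urine) for inhibition of Myeloperoxidase (Homo sapiens), with a stated time of 5 min; on this read-out higher numbers stand for weaker inhibition and lower numbers for stronger inhibition. Compound 1 `NCCCCc1c[nH]c2c(F)cccc12` gives 6 nM in this assay. Compound 2 `N#CCCCc1c[nH]c2ccc(C(=O)O)cc12` is recorded in this assay as "not active" (no number reported), with no number given. Compound 3 `CCSCCc1c[nH]c2ccc(F)cc12` reaches only a limit of the assay in this assay, > 100 nM, and not a number. Compound 3 therefore stands at the weak end of what is shown, with compound 1 the only entry carrying a definite number and compound 2 without any value at all; the one limit shown is the limit of > 100 nM in this assay, at which 1 of the 3 values shown sits.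

For the measured compounds named here, compound 4 `CCNC(=O)CCCc1c[nH]c2ccc(F)cc12` differs from compound 3 in one place: (ethylcarbamoyl)methyl in place of ethylsulfanyl on a saturated chain carbon, two bonds along the chain from an aromatic carbon No measured step between these two compounds exists. The change from compound 3 to compound 4 is expected to move the value by a step that the limit leaves unreadable from compound 3 to compound 4, a shift that cannot be judged against the scatter because compound 3 has only a limit. Compound 4 is estimated at 300 nM in this assay, between 60 nM and 3000 nM, with a fair chance that only a limit is reported again.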

Compound 4, half-maximal inhibitory concentration: 182 nM
Compound 4: the middle estimate sits 1.6-fold (0.22 log units) above what was measured; the measured number falls inside the stated range.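

The step from compound 3 to compound 4 cannot be read, because compound 3 carries only a limit of the assay and not a number: the limit of > 100 nM in this assay, at which 1 of the 4 values shown sits. The compounds shown leave open whether (ethylcarbamoyl)methyl in place of ethylsulfanyl strengthens or weakens inhibition, and by how much.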